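Shortening the amide arm from benzyl to phenyl

This account rests on a few compounds, and the source may have more. Where it says the series, first, only, none or still open, it means among the compounds named here.

Three compounds built on the shared core seen in compound 1 `CCCNc1nc(NCc2ccc(C(=O)NCc3ccc(F)cc3)cc2)c2cc(C)ccc2n1` have been measured in a functional assay on SW480 cells (Homo sapiens) for inhibition, read by luminescence and resazurin assay, with a stated time of 3 days; a lower number here means a stronger inhibitor, a higher number a weaker inhibitor. In this assay compound 1 gives 2200 nM. Compound 3 `Cc1ccc2nc(N3CCNC(C)C3)nc(NCc3ccc(C(=O)NCc4ccc(F)cc4)cc3)c2c1` gives 1400 nM, and compound 2 `CCCNc1nc(NCc2ccc(C(=O)N3CCC(C(=O)NCc4ccc(F)cc4)CC3)cc2)c2ccccc2n1`, which carries an extra ring between the central amide and the fluorinated ring, gives 5700 nM. Compound 1 therefore stands second highest of the three numbers: the step of a 1.6-fold lower number from compound 1 to compound 3 (0.20 log units; within the scatter) lies within the scatter, whereas compound 2 sits beyond it on the weaker side.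

Compound 4 `CCCNc1nc(NCc2ccc(C(=O)Nc3ccc(F)cc3)cc2)c2cc(C)ccc2n1` differs from compound 1 in one place: 4-fluorophenyl in place of 4-fluorobenzyl on an amide-type nitrogen. Among the compounds with values here, none of the measured steps covers this change. Within the data shown here, the only compound that alters the same arm is compound 2, and its higher number shows only that lengthening that arm did not help; shortening it has no precedent here. A step within the scatter is therefore the expectation, with a slight lean toward a weaker result. Compound 4 is expected to give 3000 nM, within a range of 1000 nM to 10000 nM. The expected step is a 1.4-fold higher number from compound 1 to compound 4 (0.13 log units; within the scatter).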

Compound 4, half-maximal inhibitory concentration: 1300 nM
Compound 4: the middle estimate sits 2.3-fold (0.36 log units) above what was measured; the range from low to high includes it.
By their numbers in this assay, from the lowest: compounds 4, 3 and 1 (each within the scatter of the next); then compound 2.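

In this assay, replacing 4-fluorobenzyl, with 8 heavy atoms, by 4-fluorophenyl, with 7, on the amide-type nitrogen gives a 1.7-fold lower number from compound 1 to compound 4 (0.23 log units; within the scatter). This is the first step among the compounds shown that changes this arm in one place alone, and it shows that the number stays within the scatter when the (4-fluorobenzyl)carbamoyl group becomes (4-fluorophenyl)carbamoyl. No available evidence bears on this result, so nothing can be said about what lies behind it.

The compounds shown leave open whether the fluorine itself matters, which a plain phenyl group on the same nitrogen would test, and whether a longer chain such as 2-(4-fluorophenyl)ethyl would move the number beyond the scatter. They also leave open whether a phenyl ring carrying an amine or a carboxylic acid would be tolerated here, and whether the 4-fluorophenyl swap gives a similar step alongside the 3-methylpiperazin-1-yl group of compound 3.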